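Replacing the chloro group of compound 2 with hydrogen

The compounds below may be only part of what the source reports. "The series", "measured", "known", "first", "only" and "open" are said of these compounds alone.

In a functional assay on K562 cells (Homo sapiens) for cytotoxicity, read by MTT assay, with a stated time of 48 h (on this read-out higher numbers stand for weaker inhibition and lower numbers for stronger inhibition), compound 1 `CCOC(=O)[C@]1(C(=O)Nc2ccccc2)C[C@@H]1c1cc(OC)c(OC)c(OC)c1` gives > 100000 nM as a limit of the assay, not a number. Compound 2 `CCOC(=O)[C@@]1(C(=O)Nc2ccccc2Cl)C[C@H]1c1cc(OC)c(OC)c(OC)c1` likewise gives > 100000 nM as a limit, so it stands at the only level seen so far. Compound 3 `CCOC(=O)[C@@]1(C(=O)Nc2ccccc2)C[C@H]1c1cc(OC)c(OC)c(OC)c1` differs from compound 2 by hydrogen in place of chloro on an aromatic carbon, ortho to a large group (hydrogen in place of chloro on an aromatic carbon). For the measured compounds named here, no measured step guides this change. The expected step of a number no higher from compound 2 to compound 3 (the limit leaves the size open) in this assay is none beyond the scatter, with no direction foreseen. For compound 3 the estimate is 100000 nM with an expected range from 40000 nM to 200000 nM and a further limit is the likeliest report.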

Compound 3, half-maximal inhibitory concentration: > 100000 nM
Compound 3: only a limit was reported; the forecaster's own chance of this, stated with the estimate: 75%; the middle value sits exactly at the limit.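

Compound 3 is reported only as a limit, as are compound 1 and compound 2, so neither step to compound 3 can be read: the limit of > 100000 nM in this assay, at which 3 of the 3 values shown sit.

The compounds shown leave open whether replacing chloro with hydrogen or inverting the configuration changes cytotoxicity at all.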